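A few compounds are considered here, and "the series" means these few. Any claim that something is new, unique, unknown or untested is made for them only; others in the source may bear on it.

Measured compounds:
- compound 1, `O=C(NS(=O)(=O)c1ccccc1)c1ccc(Nc2nc(NC3(c4ccc(Cl)cc4)CC3)nc(OCC(F)(F)F)n2)cc1`, 182 nm/s
- compound 2, `CC(C)(C)OC(=O)NCCS(=O)(=O)NC(=O)c1ccc(Nc2nc(NC3(c4ccc(Cl)cc4)CC3)nc(OCC(F)(F)F)n2)cc1`, 111 nm/s
- compound 3, `CC(C)C(=O)NCCS(=O)(=O)NC(=O)c1ccc(Nc2nc(NC3(c4ccc(Cl)cc4)CC3)nc(OCC(F)(F)F)n2)cc1`, 13 nm/s

All three were run in a physicochemical assay for permeability, using PAMPA, at pH 7.4; a lower number here means that the compound crosses the layer more slowly, a higher number that the compound crosses the layer faster. Compound 3 stands lowest of the three numbers: compound 2 is its nearest neighbour, an 8.5-fold lower number from compound 2 to compound 3 (0.93 log units; beyond the scatter), and compound 1 the furthest, a 14-fold lower number from compound 1 to compound 3 (1.15 log units; beyond the scatter). By contrast the step from the phenyl sulfonamide to the carbamate, a 1.6-fold lower number from compound 1 to compound 2 (0.21 log units; within the scatter), stayed within the scatter.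

Compound 4, `CNC(=O)NCCS(=O)(=O)NC(=O)c1ccc(Nc2nc(NC3(c4ccc(Cl)cc4)CC3)nc(OCC(F)(F)F)n2)cc1`, has not yet been measured in this assay . It differs from compound 3 in one place: methylamino in place of isopropyl on a carbonyl carbon. The step that bears most directly on this is the one on the same carbonyl carbon, an 8.5-fold lower number from compound 2 to compound 3 (0.93 log units; beyond the scatter), which was modest and downward; the step of a 14-fold lower number from compound 1 to compound 3 (1.15 log units; beyond the scatter) shows how far this side chain has already carried the number down. Within the data shown here, there is no measured step that replaces an isopropyl on this carbonyl carbon with a methylamino, so the expectation rests on the direction of the two downward steps and on compound 3 already standing at the low end. A further modest downward step is expected, a 1.9-fold lower number from compound 3 to compound 4 (0.27 log units; within the scatter), though a result within the scatter would not surprise. Compound 4 is therefore expected to give about 7 nm/s, between 2 nm/s and 25 nm/s.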

Compound 4, apparent permeability: 40 nm/s
Beside the measured number, compound 4's estimate is 5.7-fold (0.76 log units) below it, and the stated range ends below it.
By their numbers in this assay, from the lowest: compound 3; then compound 4; then compounds 2 and 1 (each within the scatter of the next).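

In this assay, the carbonyl carbon in this side chain proves able to move the number upward as well as downward: methylamino in place of isopropyl gives a 3.1-fold higher number from compound 3 to compound 4 (0.49 log units; beyond the scatter), whereas the earlier change on this carbon, from tert-butoxy to isopropyl, had only lowered it. This recovery is partial, with a 2.8-fold lower number from compound 2 to compound 4 (0.44 log units; beyond the scatter) on the same carbonyl carbon and a 4.6-fold lower number from compound 1 to compound 4 (0.66 log units; beyond the scatter) when the whole 2-((methylcarbamoyl)amino)ethyl group is set against phenyl on the sulfonyl sulfur, so that here the number stays short of those of both earlier compounds. The change brings in a nitrogen and 1 hydrogen-bond donor, but no measurement available here accounts for the rise.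

The compounds shown leave open whether the rise follows from the entering nitrogen or from the loss of the branched isopropyl, a question that ethylamino, dimethylamino or methoxy on the same carbonyl carbon could help to settle. They also leave open how the number would respond to a longer chain on the sulfonyl sulfur carrying the same methylcarbamoyl group.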